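Acetamido in place of cyclopropylamino on the shared core

The source may hold more compounds than are shown below. What is called first, only, known or untested is meant among the compounds shown, and "the series" means these compounds.

Measured compounds:
compound 1 `COc1c(NS(=O)(=O)c2ccc(F)cc2)cc(-c2ccc3nc(NC4CC4)sc3n2)cc1C(N)=O`: 35700 nM
compound 2 `NC(=O)c1cc(-c2ccc3nc(NC(=O)C4CC4)sc3c2)cc(NS(=O)(=O)c2ccc(F)cc2)c1Cl`: 11400 nM

Of the compounds shown here, two have been measured in a functional assay on HCT-116 cells (Homo sapiens) for antiproliferative activity, read by MTT assay, with a stated time of 72 h; a lower number here means a stronger inhibitor, a higher number a weaker inhibitor. Compound 1 gives 35700 nM, the highest of the two numbers. Compound 2 gives 11400 nM, a lower number, and the gap between the two lies beyond the scatter. Going by the values given here, compound 2 differs from compound 1 in several places at once, so no single step connects them, and its value only shows that a lower number is reachable.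

Compound 3 `COc1c(NS(=O)(=O)c2ccc(F)cc2)cc(-c2ccc3nc(NC(C)=O)sc3n2)cc1C(N)=O` differs from compound 1 in one place: acetyl in place of cyclopropyl on a nitrogen on an aromatic ring. Among the compounds with values here, the nitrogen on the aromatic ring keeps its one other neighbour, an aromatic carbon.

Nothing measured isolates this change, so the direction is uncertain. Compound 2 also carries an acyl group on the corresponding nitrogen and gives a lower number, but its other differences prevent any reading of that as a cause. A modest step toward a lower number is expected for compound 3, possibly within the scatter, as a 1.6-fold lower number from compound 1 to compound 3 (0.21 log units; within the scatter). Compound 3 is estimated at 22000 nM, with a range from 7000 nM to 60000 nM.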

Compound 3, half-maximal inhibitory concentration: 4250 nM
Estimate against measurement, compound 3: 5.2-fold (0.71 log units) above; the measured number lies below the stated range.
By their numbers in this assay, from the lowest: compound 3; then compound 2; then compound 1.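

In this assay, going by these compounds alone, the nitrogen on the aromatic ring proves sensitive to the group it carries: acetyl in place of cyclopropyl gives an 8.4-fold lower number from compound 1 to compound 3 (0.92 log units; beyond the scatter) and is the first single change that can be read at all. The two groups have the same count of heavy atoms, so that count alone does not set the number at this place; what changes is that a three-membered carbon ring leaves and a carbonyl, with its one hydrogen-bond acceptor, enters. No measurement shown bears on why the number falls, so the step stands as an observation without an explanation.

The compounds shown leave open whether this step belongs to the acetyl group in particular or would extend to other groups on this nitrogen, such as a free amine, a propionyl group with its longer chain, or a methylsulfonyl group. Compound 2 also carries an acyl group on the corresponding nitrogen, but it differs from compound 3 in several places, so it cannot settle that question.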